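Benzyl in place of methyl on the selenium of compound 1

The compounds below may be only part of what the source reports. "The series", "measured", "known", "first", "only" and "open" are said of these compounds alone.

Compound 1 `C[Se]/C(=N\C(=O)c1cc2ccccc2s1)NC(=O)c1cc2ccccc2s1` is tested in a functional assay on MCF7 cells (Homo sapiens) for cytotoxicity, read by MTT assay, with a stated time of 72 h (a lower number here means a stronger inhibitor of growth, a higher number a weaker inhibitor of growth), where compound 1 gives 5070 nM. Its nearest companion is compound 2 `O=C(/N=C(/NC(=O)c1cc(-c2ccccc2)nc2ccccc12)[Se]Cc1ccccc1)c1cc(-c2ccccc2)nc2ccccc12`, which in this assay gives 8460 nM; the two numbers lie within the usual scatter of each other. Compound 3 `O=C(/N=C(/NC(=O)c1cc2ccccc2s1)[Se]Cc1ccccc1)c1cc2ccccc2s1` keeps the core of compound 1 and carries the change (phenyl in place of hydrogen on a saturated chain carbon bound to a selenium atom). Within the data shown here, no pair of measured compounds shows this exact change, so the step from compound 1 to compound 3 is estimated as a 1.2-fold higher number from compound 1 to compound 3 (0.07 log units; within the scatter), not expected to go beyond the scatter. Compound 3 is therefore expected to give about 6000 nM, within 2500 nM to 15000 nM.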

Compound 3, concentration for 50% growth inhibition: 37900 nM
Estimate against measurement, compound 3: 6.3-fold (0.80 log units) below; the measured number lies above the stated range.
By their numbers in this assay, from the lowest: compounds 1 and 2 (each within the scatter of the next); then compound 3.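

Putting benzyl in place of methyl on the selenium, with the rest of the molecule unchanged, gives a 7.5-fold higher number from compound 1 to compound 3 (0.87 log units; beyond the scatter), a clear loss of growth inhibition. This shows that the group on the selenium matters, which compound 1 and compound 2 could not show, since they differ in more than one place. Nothing measured here explains the loss.

Still open, going by these compounds, is whether an ethyl group or a longer chain on the selenium would behave like methyl or like benzyl. On these data alone, the effect of an amine or a carboxylic acid on the benzyl ring also remains unknown.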